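The source may report more compounds than this note shows. Statements on the series, on what has been measured and on what is new or still open speak of the compounds shown alone.

In a functional assay on DU-145 cells (Homo sapiens) for inhibition (on this read-out lower numbers stand for stronger inhibition and higher numbers for weaker inhibition), compound 1, `Oc1ccc(-c2cc(-c3ccc(F)cc3)cc(-c3ccccc3O)n2)cc1`, gives a value that is only a limit of the assay, > 50000 nM. Compound 2, `Oc1ccc(-c2cc(-c3ccc(F)cc3)cc(-c3cccc(O)c3)n2)cc1`, gives in this assay a value of 15200 nM. The change between them is 3-hydroxyphenyl in place of 2-hydroxyphenyl on an aromatic carbon, and it brings an at least 3.2-fold lower number from compound 1 to compound 2 (0.51 log units; beyond the scatter); because of the limit of > 50000 nM in this assay, at which 2 of the 3 values shown sit, the size of that step is known only as a lower bound. Compound 3, `Oc1cccc(-c2cc(-c3cccc(OC(F)(F)F)c3)cc(-c3ccccc3O)n2)c1`, also gives in this assay only a limit, > 50000 nM. How the core of compound 3 differs from the core of compound 1 is not broken down here. Compound 4, `Oc1cccc(-c2cc(-c3cccc(OC(F)(F)F)c3)cc(-c3cccc(O)c3)n2)c1`, stands to compound 3 as compound 2 stands to compound 1: the change is 3-hydroxyphenyl in place of 2-hydroxyphenyl on an aromatic carbon. Within the data shown here, it is the same kind of change as the one from compound 1 to compound 2, not the same, since around the place it sits meta to a 3-hydroxyphenyl group and meta to a large group, whereas in compound 1 the place sits meta to a 4-fluorophenyl group and meta to a 4-hydroxyphenyl group. Since compound 3 is known only by its limit > 50000 nM, the expected step of an at least 1.6-fold lower number from compound 3 to compound 4 (0.22 log units; that floor lies within the scatter) is set beside an at least 3.2-fold lower number from compound 1 to compound 2 (0.51 log units; beyond the scatter) with little confidence, and the estimate for compound 4 in this assay is 30000 nM, with a range from 8000 nM to 100000 nM expected.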

Compound 4, half-maximal inhibitory concentration: > 50000 nM
Compound 4: only a limit was reported; the forecaster's own chance of this, stated with the estimate: 45%; at least 1.6-fold (0.22 log units) between middle value and limit.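

In this assay compound 4 gives only a limit, > 50000 nM. Compound 3 also stands at a limit, so the step between compound 3 and compound 4 cannot be read, because of this: the limit of > 50000 nM in this assay, at which 3 of the 4 values shown sit. Going by these compounds, it remains open whether the change from 2-hydroxyphenyl to 3-hydroxyphenyl, which gave a readable lower bound between compound 1 and compound 2, has any effect in the setting of compound 3.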